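A few compounds are considered here, and "the series" means these few. Any claim that something is new, unique, unknown or untested is made for them only; others in the source may bear on it.

Series notes. The three measured compounds share one core and differ only in the group on a saturated chain carbon bound to an amide-type nitrogen: compound 1 `CCC(NC(=O)C(CC(C)C)NC(=O)OCc1ccccc1)C(=O)C(=O)NCC1(C)CC(O)CC(C)(C)C1`, compound 2 `CCC(NC(=O)C(CC(C)C)NC(=O)OCc1ccccc1)C(=O)C(=O)NCc1cc(OC)cc(OC)c1` and compound 3 `CCC(NC(=O)C(CC(C)C)NC(=O)OCc1ccccc1)C(=O)C(=O)NCc1cccnc1`. In an assay on isolated protein (Oryctolagus cuniculus) for inhibition of Calpain-2 catalytic subunit (Homo sapiens) (on this read-out higher numbers stand for weaker inhibition and lower numbers for stronger inhibition), compound 1 gives 69 nM, compound 2 gives 22 nM and compound 3 gives 120 nM. Compound 2 stands lowest of the three; the change a 3.1-fold lower number from compound 1 to compound 2 (0.50 log units; beyond the scatter) lies beyond the scatter, as does a 5.5-fold higher number from compound 2 to compound 3 (0.74 log units; beyond the scatter), while a 1.7-fold higher number from compound 1 to compound 3 (0.24 log units; within the scatter) stays within it.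

Compound 4 `CCC(NC(=O)C(CC(C)C)NC(=O)OCc1ccccc1)C(=O)C(=O)NCCCN1CCCc2ccccc21` is not yet measured. It differs from compound 2 by 2-(1,2,3,4-tetrahydroquinolin-1-yl)ethyl in place of 3,5-dimethoxyphenyl on a saturated chain carbon bound to an amide-type nitrogen. Both measured steps at this position bear on it: each exchange of the group on this carbon moved this assay by a modest amount, and every group tried in place of 3,5-dimethoxyphenyl gave a higher number. A step of similar modest size, towards a higher number, is therefore expected for compound 4, with the direction not certain given that a six-membered aromatic ring of carbon only is retained in the entering group.

The estimate for compound 4 in this assay is 60 nM, within 20 nM to 200 nM, which amounts to an expected step of a 2.7-fold higher number from compound 2 to compound 4 (0.44 log units; beyond the scatter).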

Compound 4, inhibition constant: 200 nM
Compound 4: the middle estimate sits 3.3-fold (0.52 log units) below what was measured; the range from low to high includes it.
By their numbers in this assay, from the lowest: compound 2; then compounds 1, 3 and 4 (each within the scatter of the next, the first and the last beyond it).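

In this assay, keeping a six-membered aromatic ring of carbon only in the entering group does not hold the number of compound 2: 2-(1,2,3,4-tetrahydroquinolin-1-yl)ethyl in place of 3,5-dimethoxyphenyl gives a 9.1-fold higher number from compound 2 to compound 4 (0.96 log units; beyond the scatter), so all three groups tried in place of 3,5-dimethoxyphenyl now give higher numbers and compound 2 is the strongest of the four. The two other new steps place compound 4 with compound 3 and apart from compound 1: a 1.7-fold higher number from compound 3 to compound 4 (0.22 log units; within the scatter) leaves 2-(1,2,3,4-tetrahydroquinolin-1-yl)ethyl and pyridin-3-yl unresolved on this carbon, whereas a 2.9-fold higher number from compound 1 to compound 4 (0.46 log units; beyond the scatter) separates a pair of groups at this position, something compound 3 did not do against compound 1. Nothing available accounts for these differences.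

Compound 4 changes the ring system and the chain on this carbon in a single exchange, so the compounds shown do not divide the step between those two parts. Also open, on these data alone, is whether a 3,5-dimethoxyphenyl carried on an ethyl chain, a plain phenyl, or a phenyl with a single methoxy group would stay with compound 2 or move towards compound 3 and compound 4.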